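A few compounds are considered here, and "the series" means these few. Any claim that something is new, unique, unknown or untested is made for them only; others in the source may bear on it.

Compound 2 `Cc1cc(C)c(S(=O)(=O)N2CCC(N3CCCCC3)CC2)c(C)c1` carries piperidin-1-yl on a saturated ring carbon of the shared core. For the measured compounds named here, in a functional assay on DLD-1 cells (Homo sapiens) for antiproliferative activity, read by CellTiter-Glo, with a stated time of 72 h (on this read-out higher numbers stand for weaker inhibition and lower numbers for stronger inhibition), compound 2 gives 2200 nM, the only plain number in this set. Compound 1 `Cc1cc(C)c(S(=O)(=O)N2CCC(c3ccccc3)CC2)c(C)c1` bears phenyl at the same position. In this assay compound 1 gives > 5000 nM, which is a limit of the assay and not a number, (the limit of > 5000 nM in this assay, at which 1 of the 2 values shown sits). Going by the values given here, the single measured step, an at least 2.2-fold lower number from compound 1 to compound 2 (0.35 log units; beyond the scatter), is the only comparison that touches this position. Compound 3 `Cc1cc(C)c(S(=O)(=O)N2CCC(N3CC(C)CC(C)C3)CC2)c(C)c1` differs from compound 2 by 3,5-dimethylpiperidin-1-yl in place of piperidin-1-yl on a saturated ring carbon. Among the compounds with values here, no measured step adds methyl groups to that piperidine, so the earlier step is only a loose guide, and no movement beyond the scatter is expected. Compound 3 is therefore estimated at 1500 nM, expected between 500 nM and 5000 nM. The expected step is a 1.5-fold lower number from compound 2 to compound 3 (0.17 log units; within the scatter), within the usual scatter.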

Compound 3, half-maximal inhibitory concentration: 17 nM
Compound 3: the middle estimate sits 88-fold (1.95 log units) above what was measured; the whole stated range lies above it.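

The two added methyl groups do far more than the earlier exchange suggested: 3,5-dimethylpiperidin-1-yl in place of piperidin-1-yl gives a 130-fold lower number from compound 2 to compound 3 (2.11 log units; beyond the scatter), so this position responds strongly to a change on the piperidine itself, and not only to the exchange of phenyl for piperidin-1-yl, which gave an at least 2.2-fold lower number from compound 1 to compound 2 (0.35 log units; beyond the scatter). Set against phenyl, the same group gives an at least 290-fold lower number from compound 1 to compound 3 (2.46 log units; beyond the scatter). Compound 1 stands at a limit of the assay and not at a number, so this step is only a bound: the limit of > 5000 nM in this assay, at which 1 of the 3 values shown sits.

The compounds shown leave open whether a single methyl group on the piperidine would be enough, and whether ethyl groups or a morpholine ring would hold the gain. They also leave open how the two methyl groups are arranged relative to each other, and whether that arrangement matters.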